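Aryl swap from compound 3 to compound 4

The source may report more compounds than this note shows. Statements on the series, on what has been measured and on what is new or still open speak of the compounds shown alone.

Compound 1 `COc1ccc(C(=O)/C(=C/c2ccc(Cl)cc2Cl)CCOC(C)=O)cc1` in a functional assay on A549 cells (Homo sapiens) for inhibition, read by XTT assay, with a stated time of 48 h (a lower number here means a stronger inhibitor, a higher number a weaker inhibitor), gives 69200 nM.
Compound 2 `COc1ccc(C(=O)/C(=C/c2ccccc2Cl)CCOC(C)=O)cc1` in this assay gives > 100000 nM, which is a limit of the assay and not a number.
Compound 3 `C=C(C(=O)c1ccc(OC)cc1)C(OC(C)=O)c1ccccc1F` in this assay gives 67300 nM.

Compound 3 holds the lowest of the two numbers in the set; its nearest neighbour is compound 1, and the gap between them lies within the scatter, so no order between the two is claimed. Compound 4 `C=C(C(=O)c1ccc(OC)cc1)C(OC(C)=O)c1ccc(Cl)cc1Cl` carries 2,4-dichlorophenyl in place of 2-fluorophenyl on a saturated chain carbon bound to a double-bonded chain carbon and an oxygen next to a carbonyl group. Within the data shown here, only one measured step touches a ring halogen: an at least 1.4-fold higher number from compound 1 to compound 2 (0.15 log units; that floor lies within the scatter), which runs on a different core, removes a chloro rather than exchanging fluoro for two chloro, and has its floor set by the limit of > 100000 nM in this assay, at which 1 of the 3 values shown sits, a floor that itself lies within the scatter. Read in reverse it offers at most a weak hint that the dichlorophenyl may lower the number; compound 3 and compound 1 sitting at the same level give no further direction. For compound 4 in this assay a step of a 1.3-fold lower number from compound 3 to compound 4 (0.13 log units; within the scatter) is therefore expected, with the estimate at 50000 nM and a range from 20000 nM to 120000 nM.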

Compound 4, half-maximal inhibitory concentration: 17600 nM
For compound 4 the middle estimate is 2.8-fold (0.45 log units) above the measured one; measured number outside the range, below it.
By their numbers in this assay, from the lowest: compound 4; then compounds 3 and 1 (each within the scatter of the next). At a limit, above all of these: compound 2.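

Among these compounds, on the shared core of compound 3 and compound 4, the aryl group on a saturated chain carbon bound to a double-bonded chain carbon and an oxygen next to a carbonyl group now gives the first ring-halogen change beyond the scatter in this assay (a 3.8-fold lower number from compound 3 to compound 4 (0.58 log units; beyond the scatter)). The earlier ring-halogen step gave only a floor within the scatter on a different core, whereas this step is a full measured pair and shows that the number responds to the aryl group at this place. The change is modest, and nothing at hand gives a cause for it.

Among the compounds shown here, the single swap removes fluoro and brings in two chloro at once, so the share of each remains unresolved. A 2-chlorophenyl, a 4-chlorophenyl or a 4-methoxyphenyl at this place would test how far the step depends on the halogens.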